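The source may report more compounds than this note shows. Statements on the series, on what has been measured and on what is new or still open speak of the compounds shown alone.

Two compounds of the series have been run so far in an assay on isolated protein for inhibition of tyrosine-protein kinase receptor UFO (Homo sapiens), read by FRET and Z'-LYTE, with a stated time of 1.5 h; on this read-out lower numbers stand for stronger inhibition and higher numbers for weaker inhibition. Compound 1 `Cc1c(C(=O)Nc2ccc(Oc3ncnc4[nH]cc(-c5ccccc5)c34)c(F)c2)c(=O)c2cc(Br)ccc2n1C` gives 3120 nM in this assay, while compound 2 `Cc1ccc2[nH]c(C)c(C(=O)Nc3ccc(Oc4ncnc5[nH]cc(-c6ccccc6)c45)c(F)c3)c(=O)c2c1` gives 560 nM in this assay, the lower of the two numbers, with compound 1 beyond the scatter from it. Compound 3 `CCCn1c(C)c(C(=O)Nc2ccc(Oc3ncnc4[nH]cc(-c5ccccc5)c34)c(F)c2)c(=O)c2cc(C)ccc21` differs from compound 2 by propyl in place of hydrogen on an aromatic nitrogen. Among the measured compounds shown here, no single-change step of this kind has been measured. A move toward weaker inhibition beyond the scatter is expected, because compound 1 with an alkyl group on an aromatic nitrogen gives 3120 nM. The expected step is a 2.3-fold higher number from compound 2 to compound 3 (0.37 log units; beyond the scatter). Compound 3 is estimated at 1300 nM, within 400 nM to 4500 nM.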

Compound 3, half-maximal inhibitory concentration: 530 nM
Compound 3: middle estimate off by 2.5-fold (0.39 log units), on the high side; the range from low to high includes it.
By their numbers in this assay, from the lowest: compounds 3 and 2 (each within the scatter of the next); then compound 1.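

In this assay, propyl in place of hydrogen on the aromatic nitrogen gives a 1.1-fold lower number from compound 2 to compound 3 (0.02 log units; within the scatter), so the hydrogen at this position can be replaced by this chain without a step beyond the scatter. Compound 1 also carries an alkyl group on an aromatic nitrogen but differs in another place as well, so its value does not bear on this single change. No measurement at hand accounts for this result. Open, from the compounds shown here alone, is whether a longer chain, a terminal amine or a carboxylic acid on this nitrogen would also stay within the scatter of compound 2.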